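The source may report more compounds than this note shows. Statements on the series, on what has been measured and on what is new or still open speak of the compounds shown alone.

Within the data shown here, compound 1 `CC(C)c1nn(-c2ccc(C(N)=O)c(N[C@H]3CC[C@H](O)CC3)c2)c2nccc(-n3cnc(-c4ccncc4)c3)c12` is one of three compounds measured in a functional assay on SK-BR-3 cells (Homo sapiens) for inhibition, read by CellTiter-Glo, with a stated time of 72 h (a higher number here means a weaker inhibitor, a lower number a stronger inhibitor), where compound 1 gives 165 nM. That places it second highest of the three. Compound 3 `CC(C)c1nn(-c2ccc(C(N)=O)c(N[C@H]3CC[C@H](O)CC3)c2)c2cccc(-c3cnc4ccccc4c3)c12` gives 39 nM in this assay, a lower number than compound 1 by a margin beyond the scatter, while compound 2 `CNc1cc(-n2nc(C(C)C)c3c(-n4cnc(-c5cnn(C)c5)c4)ccnc32)ccc1C(N)=O` gives 773 nM, a higher number than compound 1, again beyond the scatter. Among the measured compounds shown here, neither of those two differs from compound 1 in a single place, so no step between measured compounds is available to lean on.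

Compound 4 `CC(C)c1nn(-c2ccc(C(N)=O)c(N[C@H]3CC[C@H](O)CC3)c2)c2nccc(-c3cccnc3)c12` is not yet measured. It differs from compound 1 in one place: pyridin-3-yl in place of 4-(pyridin-4-yl)-1H-imidazol-1-yl on an aromatic carbon. For the measured compounds named here, with no measured step covering such a change, the expectation for compound 4 rests on the spread of the three numbers alone. The step from compound 1 to compound 4 in this assay is expected to be a 1.3-fold higher number from compound 1 to compound 4 (0.12 log units; within the scatter), which could fall within the scatter in either direction. Compound 4 is estimated at 220 nM, with a range from 60 nM to 800 nM.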

Compound 4, half-maximal inhibitory concentration: 464 nM
Compound 4: the middle estimate sits 2.1-fold (0.32 log units) below what was measured; the range from low to high includes it.
By their numbers in this assay, from the lowest: compound 3; then compound 1; then compounds 4 and 2 (each within the scatter of the next).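

At this aromatic carbon, opposite the ring nitrogen, the result gives the first single-place measure of what the substituent contributes: in this assay exchanging 4-(pyridin-4-yl)-1H-imidazol-1-yl for pyridin-3-yl gives a 2.8-fold higher number from compound 1 to compound 4 (0.45 log units; beyond the scatter) and this modest step lies beyond the scatter. The change removes the five-membered aromatic ring and leaves a single six-membered aromatic ring, with fewer heavy atoms and hydrogen-bond acceptors, so the number rises but only modestly. No available evidence accounts for the size or direction of this step.

The compounds shown do not separate the loss of the five-membered ring from the altered placement of the pyridine nitrogen. On these data alone, how a plain phenyl or a morpholine on this carbon would compare with pyridin-3-yl remains open.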